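The source may report more compounds than this note shows. Statements on the series, on what has been measured and on what is new or still open speak of the compounds shown alone.

In a functional assay on MT4 cells (Homo sapiens) for antiproliferative activity, read by MTT assay, with a stated time of 96 h (on this read-out lower numbers stand for stronger inhibition and higher numbers for weaker inhibition), three related compounds have been measured. Compound 1 `O=C1NNC(=O)C2(CSC3=C2C(=O)c2ncccc2C3=O)N1` gives 550 nM; 500 nM; 550 nM (3 entries), and compound 3 `O=C1NN(c2ccccc2)C(=O)C2(CSC3=C2C(=O)c2ncccc2C3=O)N1` gives 150 nM. Compound 2 `O=C1C2=C(C(=O)c3ncccc31)C1(CS2)NC(=O)N(c2ccccc2)C1=O` gives 25 nM, the lowest number of the three, and its gap to compound 3 lies beyond the usual scatter. Compound 4 `COc1ccc(N2C(=O)NC3(CSC4=C3C(=O)c3ncccc3C4=O)C2=O)cc1` differs from compound 2 in one place: methoxy in place of hydrogen on an aromatic carbon. This puts methoxy in place of hydrogen on an aromatic carbon, turning phenyl to 4-methoxyphenyl. For the measured compounds named here, no measured pair shows what this change does. The expected step of a 1.2-fold higher number from compound 2 to compound 4 (0.08 log units; within the scatter) is small and stays within the usual scatter of this assay. For compound 4, the estimated value is 30 nM, with an expected range of 10 nM to 90 nM.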

Compound 4, half-maximal inhibitory concentration: 70 nM
Beside the measured number, compound 4's estimate is 2.3-fold (0.37 log units) below it; measured number inside the range.
By their numbers in this assay, from the lowest: compound 2; then compound 4; then compound 3.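

In this assay, methoxy on the phenyl ring, para to a large group, gives a 2.8-fold higher number from compound 2 to compound 4 (0.45 log units; beyond the scatter), so this change weakens inhibition modestly without abolishing it. For the compounds shown here, this is the first look at a substituent on that ring, and it shows that the position accepts methoxy at a small cost. Repeat readings agree closely in this assay, which supports reading the step as real: the several entries of compound 1 in this assay, 550 nM; 500 nM; 550 nM (3 entries)

From the compounds shown here alone, whether any group at this place costs as much stays open, since a fluorine, a methyl or an amine could answer differently. Also open, going by these compounds, is whether methoxy would have the same effect on the phenyl of compound 3.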